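Bicyclic triazole series: an ethoxy in the chain position

This account rests on a few compounds, and the source may have more. Where it says the series, first, only, none or still open, it means among the compounds named here.

Measured so far in a functional assay on the whole organism (strain ICR) for inhibition, with Mus musculus as the target, with a stated time of 16 h, at a dose of 10 mg/kg by the oral route; on this read-out lower numbers stand for less inhibition and higher numbers for more inhibition at the one dose given (going by the name of the read-out):
- compound 1, `CCS(=O)(=O)CCC12CCC(c3nnc(-c4ccccc4C)n3C)(CC1)CC2`: 30%
- compound 2, `Cn1c(-c2ccccc2C(F)(F)F)nnc1C12CCC(CNS(C)(=O)=O)(CC1)CC2`: 27%
- compound 3, `Cn1c(-c2ccccc2C(F)(F)F)nnc1C12CCC(CCCC(C)(F)F)(CC1)CC2`: 94%

Compound 3 holds the highest number of the three. Its nearest neighbour is compound 1, and the gap to compound 1 as well as the gap to compound 2 is beyond the scatter, so compound 3 stands with the highest inhibition in this assay of the measured set.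

Compound 4, `CCOCC12CCC(c3nnc(-c4ccccc4C(F)(F)F)n3C)(CC1)CC2`, is not yet measured. It differs from compound 3 in one place: a group of 3 heavy atoms (2 carbon, 1 oxygen; no ring) in place of a group of 6 heavy atoms (4 carbon, 2 fluorine; no ring), on a saturated chain carbon bound to a saturated ring carbon.

Among the compounds with values here, one measured step bears on this place. Going a number 67 percentage points higher from compound 2 to compound 3 (beyond the scatter), the group now leaving compound 3 entered in exactly this position and carried a large gain. The group entering compound 4 brings one hydrogen-bond acceptor, as did the group that left in that step, but it is smaller and closer in count to the group of compound 3. Within the data shown here, compound 1, which carries a different chain here and a methyl on the aryl, sits far below compound 3, but no single-place step links it to compound 3.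

Some loss is therefore expected for compound 4, of moderate size: a number 39 percentage points lower from compound 3 to compound 4 (beyond the scatter). The estimate for compound 4 is 55%, with a range from 25% to 85%.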

Compound 4, a percentage reported as inhibition, in the whole organism at one dose (the size of the read-out at that dose, not a potency): 3%
The estimate for compound 4 lay 52 percentage points above the measured number; measured number below the stated range.
By their numbers in this assay, from the lowest: compound 4; then compounds 2 and 1 (each within the scatter of the next); then compound 3.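

Ethoxy on this saturated chain carbon bound to a saturated ring carbon removes nearly all of the effect in this assay, going a number 91 percentage points lower from compound 3 to compound 4 (beyond the scatter), so the large gain seen earlier at this place can be lost entirely with a single change of group. Ethoxy also falls short of methanesulfonamido, going a number 24 percentage points lower from compound 2 to compound 4 (beyond the scatter), and across compounds 4, 2 and 3 the read-out rises with the heavy-atom count of the group, from 3 to 5 to 6, although three compounds are too few to establish a trend. No measurement available here explains the drop.

Going by these compounds, it remains open whether the loss follows the shorter chain, the ether oxygen or the absence of fluorine, a question that a plain butyl chain, a longer ether such as butoxy, or a difluoroethyl group in this place would help separate. On these data alone, how an amine or a carboxylic acid at the end of the chain would fare in this assay also remains open.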